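Swapping a Nitro Group for Methoxy on an Aromatic Ester

The source may hold more compounds than are shown below. What is called first, only, known or untested is meant among the compounds shown, and "the series" means these compounds.

Compound 1, `COc1cccc(C(=O)Oc2cc3c(C)ccc(C(C)C)c3cc2C)c1`: "not active" (no number reported)
Compound 2, `Cc1cc2c(C(C)C)ccc(C)c2cc1OC(=O)c1ccc([N+](=O)[O-])cc1`: 100%

Within the data shown here, in a functional assay on U-251 cells (Homo sapiens) for antiproliferative activity, read by sulforhodamine B assay, with a stated time of 48 h, tested at 50 uM (on this read-out lower numbers stand for less inhibition and higher numbers for more inhibition at the one concentration tested (going by the name of the read-out)), compound 2 gives 100%, the only number reported, while compound 1 is recorded as "not active" (no number reported) without a figure. Compound 3, `COc1ccc(C(=O)Oc2cc3c(C)ccc(C(C)C)c3cc2C)cc1`, is the untested partner: methoxy in place of nitro on an aromatic carbon. Among the measured compounds shown here, no step between measured compounds is available to gauge this change, so the expectation rests on compound 1, which carries a methoxy group and is reported as "not active" (no number reported). A sizeable fall in inhibition is expected, a step of a number 65 percentage points lower from compound 2 to compound 3 (beyond the scatter) that would lie well beyond the usual scatter. Compound 3 is estimated at 35%, within 5% to 80%.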

Compound 3, a percentage reported as inhibition, at one concentration (the size of the read-out at that concentration, not a potency): 42.6%
Compound 3: the middle estimate sits 7.6 percentage points below what was measured, and the stated range covers the measured number.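

Among these compounds, at this place on the ring, para to a large group, going from 4-nitrophenyl to 4-methoxyphenyl gives the first measured step in this assay, a number 57.4 percentage points lower from compound 2 to compound 3 (beyond the scatter) and well past ordinary variation. The group at this one place therefore matters strongly at the single concentration tested, although compound 3 still retains 42.6% inhibition. No available evidence explains the size of this drop.

Going by these compounds, whether an amine or a carboxylic acid here would sit nearer compound 2 or compound 3 remains open. A single-concentration percentage also leaves the potency of both compounds unknown.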